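This account rests on a few compounds, and the source may have more. Where it says the series, first, only, none or still open, it means among the compounds named here.

Measured compounds:
Compound 1, `Cc1c(C(=O)c2ccc(CN(C)C)cc2)oc2cc(-c3ccccc3)cc(O)c12`, gives in a functional assay on WI-38 VA13 cells (Homo sapiens) for cytotoxicity (a lower number here means that less compound is needed, a higher number that more compound is needed for the effect), a value that is a limit of the assay, > 4 ug/mL.
Compound 2, `Cc1c(C(=O)c2cnc3ccccc3c2)oc2cc(-c3ccccc3)cc(O)c12`, gives in this assay likewise a limit, > 4 ug/mL.
Compound 3, `Cc1c(C(=O)c2cccc(C(F)(F)F)c2)oc2cc(-c3ccccc3)cc(O)c12`, gives in this assay again a limit, > 4 ug/mL.

In this assay, then, every measured value is a limit and no number; this is the limit of > 4 ug/mL in this assay, at which 3 of the 3 values shown sit. Among the measured compounds shown here, compound 1 stands exactly where the other two stand, at that limit, so nothing distinguishes it from compound 2 or compound 3 in this assay, and no measured step between any two of them exists.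

Compound 4, `Cc1c(C(=O)c2ccc(N(C)C)cc2)oc2cc(-c3ccccc3)cc(O)c12`, differs from compound 1 by dimethylamino in place of (dimethylamino)methyl on an aromatic carbon. For the measured compounds named here, with no measured step available, the three limits are the only guide, and they suggest that the change brings nothing beyond the scatter in this assay. Compound 4 is therefore expected to sit at the limit once more, with an estimated value of 8 ug/mL, in a range from 3 ug/mL to 20 ug/mL. This estimate means an expected step that the limit leaves unreadable from compound 1 to compound 4, judged to lie within the scatter.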

Compound 4, half-maximal effective concentration: > 4 ug/mL
Compound 4 was reported as a limit; the forecaster's own chance of this, stated with the estimate: 75%; the middle value is on the limit's open side.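

No step can be read from compound 1 to compound 4 in this assay, because both values are limits: the limit of > 4 ug/mL in this assay, at which 4 of the 4 values shown sit. The compounds shown leave open whether dimethylamino in place of (dimethylamino)methyl on an aromatic carbon makes any difference, and where any of these compounds would give an actual number.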